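The source may hold more compounds than are shown below. What is called first, only, known or untested is meant among the compounds shown, and "the series" means these compounds.

Measured so far:
compound 1 `CC(C)(C)Cc1c(-c2cccc(F)c2F)sc(N)c1C(=O)c1ccc(Cl)cc1`: 1%
compound 2 `COc1ccccc1-c1sc(N)c(C(=O)c2ccc(Cl)cc2)c1CC(C)(C)C`: 1%

In an assay on CHO cells for displacement of a labelled ligand from adenosine receptor A3 (Homo sapiens), read by scintillation counting, tested at 10 uM (on this read-out lower numbers stand for less inhibition and higher numbers for more inhibition at the one concentration tested (going by the name of the read-out)), compound 1 gives 1% and compound 2 gives 1%. The one step among the measured compounds, no change at the digits printed from compound 1 to compound 2 (within the scatter), lies within the scatter, so compound 2 stands level with compound 1 on the numbers shown, both at the floor of the read-out. Compound 3 `Cc1noc(C)c1-c1sc(N)c(C(=O)c2ccc(Cl)cc2)c1CC(C)(C)C` is not yet measured. Its change from compound 2 is 3,5-dimethyl-1,2-oxazol-4-yl in place of 2-methoxyphenyl on an aromatic carbon. Going by the values given here, the only step that bears on it is the earlier swap on the same aromatic carbon, no change at the digits printed from compound 1 to compound 2 (within the scatter), which did nothing beyond the scatter; that step exchanged one six-membered aromatic ring for another, whereas here a five-membered aromatic ring with 2 hetero atoms enters, so the precedent is loose. Among the compounds with values here, with both measured compounds at the floor and no step yet moving the read-out, no step beyond the scatter is expected in this assay; the expected step is a number 1 percentage points higher from compound 2 to compound 3 (within the scatter). Compound 3 is estimated at 2%, with a range of 0% to 12%.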

Compound 3, a percentage reported as inhibition, at one concentration (the size of the read-out at that concentration, not a potency): 1%
Beside the measured number, compound 3's estimate is 1 percentage points above it; measured number inside the range.
By their numbers in this assay, from the lowest: compounds 1, 2 and 3 (each within the scatter of the next).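

In this assay, 3,5-dimethyl-1,2-oxazol-4-yl in place of 2-methoxyphenyl on the aromatic carbon next to the ring sulfur gives no change at the digits printed from compound 2 to compound 3 (within the scatter), and in place of 2,3-difluorophenyl it gives no change at the digits printed from compound 1 to compound 3 (within the scatter). The earlier step only exchanged one six-membered aromatic ring of carbon only for another, whereas these steps show that a five-membered aromatic ring with 2 hetero atoms at this position also leaves the read-out at the floor, so all three aromatic groups are level here. No measurement on hand accounts for this flat result.

As far as these compounds go, whether a carboxylic acid, an amine or a plain methyl on this carbon would lift the read-out off the floor stays open. From the compounds shown here alone, it is also open whether a longer chain in place of the neopentyl group would do so.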